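Same atoms, different configuration: compound 3 awaits measurement

The source may hold more compounds than are shown below. What is called first, only, known or untested is meant among the compounds shown, and "the series" means these compounds.

Compound 1 `CC[C@@H]1O[C@H](COCc2ccccc2)[C@@H](OCc2ccccc2)[C@H](OCc2ccccc2)[C@H]1O` and compound 2 `CC(C)C[C@H]1O[C@H](COCc2ccccc2)[C@H](OCc2ccccc2)[C@H](OCc2ccccc2)[C@H]1O` have both been tested in a functional assay on HL-60 cells (Homo sapiens) for antiproliferative activity, read by MTT assay (on this read-out lower numbers stand for stronger inhibition and higher numbers for weaker inhibition), with different outcomes. Compound 1 gives 8200 nM there as a measured result. Compound 2 gives "not active" (no number reported) in this assay and so has no place on the numerical scale.

The next case is compound 3 `CC(C)C[C@@H]1O[C@H](COCc2ccccc2)[C@@H](OCc2ccccc2)[C@H](OCc2ccccc2)[C@H]1O` and the structural change from its neighbour is the two compounds have the same atoms and bonds and differ only in configuration as drawn: 2 of 5 stereo elements differ; a stereocentre at a saturated ring carbon is drawn R in compound 2 and S in compound 3; a stereocentre at a saturated ring carbon is drawn S in compound 2 and R in compound 3 with no group leaving or entering. A stereocentre is an atom whose attached groups can be arranged in two distinct ways in space, so the connections stay the same while the drawn configuration does not.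

With no number for compound 2, the size of this step cannot be fixed exactly. The expected direction is towards stronger inhibition, from no reported number to a weak but measurable value. This expectation leans on compound 1 at 8200 nM as the only measured anchor, and a result without a number remains possible. For compound 3 the estimated value is 8000 nM with an expected range from 2500 nM to 30000 nM as the likely span.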

Compound 3, half-maximal inhibitory concentration: 8500 nM
Compound 3: middle estimate off by 1.1-fold (0.03 log units), on the low side; measured number inside the range.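

This result shows that the shared core can carry the larger side chain and still give a measurable number, provided the configuration matches that of compound 1. In this assay, isopropyl in place of methyl on a saturated chain carbon bound to a saturated ring carbon gives a 1.0-fold higher number from compound 1 to compound 3 (0.02 log units; within the scatter), so compounds 1 and 3 cannot be told apart on this read-out. The contrast between the "not active" result for compound 2 and the measured result of compound 3 at 8500 nM can be traced to the drawn arrangement at two saturated ring carbons, because no atom or bond separates these compounds, as shown by this: the fact that compounds 2 and 3 differ only in the configuration as drawn

As far as these compounds go, both ring carbons switch together between compound 2 and compound 3, so it remains open whether one of them alone decides between a measurable number and "not active". From the compounds shown here alone, it also remains open how a longer chain, an amine or a carboxylic acid would read in place of the isopropyl, in either configuration.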